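The compounds below may be only part of what the source reports. "The series", "measured", "known", "first", "only" and "open" are said of these compounds alone.

In a functional assay on PC-6 cells (Homo sapiens) for cytotoxicity, read by MTT assay, with a stated time of 3 days (a lower number here means a stronger inhibitor, a higher number a weaker inhibitor), compound 1 (`CC(C)(C)c1cc2c(N/N=C/c3ccc4c(c3)CNCC4)ncnc2s1`) gives 0.069 ug/mL and compound 2 (`CN(C)Cc1ccc(/C=N/Nc2ncnc3sc(C(C)(C)C)cc23)cc1`) gives 0.107 ug/mL within the scatter of each other. For compound 3 (`CC(C)(C)c1cc2c(N/N=C/c3ccc(C(=O)O)cc3)ncnc2s1`) the change from compound 2 is carboxy in place of (dimethylamino)methyl on an aromatic carbon, para to a large group. For the measured compounds named here, no measured step covers this change, so the expectation is a judgement only: a large move towards a weaker inhibitor in this assay beyond the scatter. The estimated step is a 9.3-fold higher number from compound 2 to compound 3 (0.97 log units; beyond the scatter) as a working figure. For compound 3 the expected value is 1 ug/mL (estimated range 0.2 ug/mL to 6 ug/mL).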

Compound 3, half-maximal inhibitory concentration: 7.22 ug/mL
Compound 3: the middle estimate sits 7.2-fold (0.86 log units) below what was measured; the whole stated range lies below it.
By their numbers in this assay, from the lowest: compounds 1 and 2 (each within the scatter of the next); then compound 3.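

On this aromatic carbon, para to a large group, the substituent strongly affects the number in this assay: carboxy in place of (dimethylamino)methyl gives a 67-fold higher number from compound 2 to compound 3 (1.83 log units; beyond the scatter). This single change also swaps a group with no hydrogen-bond donor for one with a hydrogen-bond donor, so the step cannot be assigned to one feature. No measurement here explains its size. As far as these compounds go, whether the carboxy group itself or the loss of the amine drives the step remains open. A methyl ester, a primary amide or a longer chain ending in an amine at this carbon would help separate the two.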